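This account rests on a few compounds, and the source may have more. Where it says the series, first, only, none or still open, it means among the compounds named here.

Measured so far in a functional assay on A2780 cells (Homo sapiens) for cytotoxicity, read by MTT assay, with a stated time of 24 h; a lower number here means a stronger inhibitor, a higher number a weaker inhibitor:
- compound 1 `C[C@H]1O[C@]1(C)C(=O)C[C@@H]1[C@@]2(C)[C@@H](O)CCC(C)(C)[C@]2(O)CC[C@@]1(C)O`: > 10000 nM (a limit)
- compound 2 `C[C@@H]1O[C@@]1(C)C(=O)C[C@H]1[C@](C)(O)CC[C@@]2(O)C(C)(C)CCC[C@]12C`: > 10000 nM (a limit)

Compound 2 has no exact number in this assay, only the limit > 10000 nM. Compound 1 likewise gives only a limit. The record so far is thus (the limit of > 10000 nM in this assay, at which 2 of the 2 values shown sit).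

Compound 3 `C[C@H]1O[C@]1(C)C(=O)C[C@H]1[C@](C)(O)CC[C@@]2(O)C(C)(C)CCC[C@]12C` keeps the atoms and bonds of compound 2 and differs only in configuration as drawn: the two compounds have the same atoms and bonds and differ only in configuration as drawn: 2 of 6 stereo elements differ; a stereocentre at a saturated ring carbon is drawn S in compound 2 and R in compound 3; a stereocentre at a saturated ring carbon is drawn R in compound 2 and S in compound 3. Among the measured compounds shown here, no measured pair shows what such a change does, and neither compound offers a number to start from. Compound 3 is therefore expected to remain inactive at the tested concentrations and may well be reported as a limit too. The expected change is no more than the scatter, as a step that the limit leaves unreadable from compound 2 to compound 3. For compound 3 the estimated value is 15000 nM, with an expected range from 5000 nM to 40000 nM.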

Compound 3, half-maximal inhibitory concentration: > 10000 nM
Compound 3 ended at the assay's limit (the forecaster's own chance of this, stated with the estimate: 75%); the middle value does not contradict the limit.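

No step can be read among compound 1, compound 2 and compound 3 in this assay, as all three give only a limit: the limit of > 10000 nM in this assay, at which 3 of the 3 values shown sit.

The compounds shown leave open whether a change in configuration as drawn, or hydrogen in place of hydroxy on a saturated ring carbon, alters cytotoxicity at all.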